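The source may hold more compounds than are shown below. What is called first, only, known or untested is meant among the compounds shown, and "the series" means these compounds.

Two close relatives share one core and differ only in the aromatic group attached to an aromatic carbon. Compound 1 `CC(Oc1ccccc1-c1cccnc1)C1=NCCN1` carries a pyridin-3-yl group, and in an assay on CHO cells for displacement of a labelled ligand from Alpha-2C adrenergic receptor (Homo sapiens) (a higher number here means a weaker inhibitor, a lower number a stronger inhibitor), compound 1 gives 64.6 nM. Compound 2 `CC(Oc1ccccc1-c1ccncc1)C1=NCCN1` carries a pyridin-4-yl group instead, and in this assay compound 2 gives 1450 nM. Going by the values given here, that single swap produced a 22-fold higher number from compound 1 to compound 2 (1.35 log units; beyond the scatter), so compound 2 stands as the higher of the two numbers measured so far, a long way from compound 1.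

Compound 3 `CC(Oc1ccccc1-c1ccccc1O)C1=NCCN1` is the next variation. Relative to compound 2, the change is 2-hydroxyphenyl in place of pyridin-4-yl on an aromatic carbon. Among the compounds with values here, no measured step covers a hydroxyphenyl group, so the only guide is how strongly this position reacts to change: the step from compound 1 to compound 2 shows that moving one nitrogen within the attached ring already shifts the number far beyond the scatter. The direction for compound 3 is therefore uncertain, and any estimate must be wide. A modest move toward stronger binding is expected for compound 3, a 5.8-fold lower number from compound 2 to compound 3 (0.76 log units; beyond the scatter) in this assay. The estimated value for compound 3 is 250 nM, with a likely range from 40 nM to 1600 nM.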

Compound 3, inhibition constant: 1620 nM
Estimate against measurement, compound 3: 6.5-fold (0.81 log units) below; the whole stated range lies below it.
By their numbers in this assay, from the lowest: compound 1; then compounds 2 and 3 (each within the scatter of the next).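

In this assay, the change from pyridin-4-yl to 2-hydroxyphenyl gives a 1.1-fold higher number from compound 2 to compound 3 (0.05 log units; within the scatter), so a ring of carbon only with 1 hydrogen-bond donor and a ring with 1 hetero atom and 0 hydrogen-bond donors cannot be told apart here, and this position does not answer every change of group with a large shift. Pyridin-3-yl now stands apart from both other groups: replacing it with 2-hydroxyphenyl gives a 25-fold higher number from compound 1 to compound 3 (1.40 log units; beyond the scatter), which, together with the earlier step, makes compound 1 the strongest inhibitor of the three. Nothing available explains why two such different groups give matching numbers or why pyridin-3-yl differs from both.

The compounds shown leave open whether the hydroxyl of 2-hydroxyphenyl has any effect of its own, a question that a plain phenyl ring or a 3-hydroxyphenyl group at the same place could help to settle. They also leave open whether pyridin-2-yl or an aminophenyl group could match compound 1 at 64.6 nM, or whether that value belongs to pyridin-3-yl alone.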